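Closing the Amidine Nitrogen into a Six-Membered Ring

The source may report more compounds than this note shows. Statements on the series, on what has been measured and on what is new or still open speak of the compounds shown alone.

Of the compounds shown here, three with a shared core have been measured. In a functional assay on Jurkat cells (Homo sapiens) for inhibition, read by MTT assay, with a stated time of 72 h (a higher number here means a weaker inhibitor of growth, a lower number a stronger inhibitor of growth), compound 1 `Cc1ccc(-c2nn(-c3ccccc3)c(/N=C/N(C)C)c2C=O)cc1` gives 9500 nM. In this assay, going by the values given here, compound 2 `COc1ccc(-c2nn(-c3ccccc3)c(/N=C/N(C)C)c2C=O)cc1` gives 12500 nM, and the only one-place step so far, a 1.3-fold higher number from compound 1 to compound 2 (0.12 log units; within the scatter), concerns the aromatic ring. In this assay compound 3 `CCN(/C=N/c1c(C=O)c(-c2ccccc2)nn1-c1ccccc1)CC` gives 30000 nM, the highest of the three numbers and beyond the scatter from both others, so compound 3 is the weakest growth inhibitor of the set.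

Compound 4 `O=Cc1c(-c2ccccc2)nn(-c2ccccc2)c1/N=C/N1CCCCC1` has not yet been measured. It differs from compound 3 by piperidin-1-yl in place of diethylamino on a carbon with a double bond to nitrogen. Among the compounds with values here, no measured step touches this part of the molecule: the single known step, a 1.3-fold higher number from compound 1 to compound 2 (0.12 log units; within the scatter), sits on the aromatic ring and is within the scatter, so it offers no direction for a change at the amidine nitrogen. With nothing measured pointing either way, compound 4 is expected to give about 30000 nM in this assay, with a range from 12000 nM to 75000 nM. The expected step of no change at the digits printed from compound 3 to compound 4 (within the scatter) therefore lies within the scatter, in no clear direction.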

Compound 4, concentration for 50% growth inhibition: 29000 nM
Compound 4: the middle estimate sits 1.0-fold (0.01 log units) above what was measured, within the range that was stated.
By their numbers in this assay, from the lowest: compounds 1 and 2 (each within the scatter of the next); then compounds 4 and 3 (each within the scatter of the next).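

Going by these compounds alone, this is the first measured step at the amidine nitrogen. In this assay, joining the two ethyl arms of diethylamino into the six-membered ring of piperidin-1-yl gives a 1.0-fold lower number from compound 3 to compound 4 (0.01 log units; within the scatter), so the open and the ring-closed group cannot be told apart in this pair. The earlier step on the aromatic ring could not show this, and it means that ring closure alone does not separate these two compounds at this position. Nothing available explains why the two groups read alike.

Still open, going by these compounds, is how a morpholine, piperazine or pyrrolidine ring would read in place of piperidin-1-yl. Also open, on these data alone, is whether piperidin-1-yl would read the same with a methyl or methoxy group on the aromatic ring, as in compound 1 and compound 2.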